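Swapping the Pyrazole on the Shared Core

This account rests on a few compounds, and the source may have more. Where it says the series, first, only, none or still open, it means among the compounds named here.

For the measured compounds named here, compound 2 `c1cc(-c2ccn[nH]2)c2c(c1)C(c1ncc[nH]1)CC2` carries a 1H-pyrazol-5-yl group on the shared core and gives 52 nM in a functional assay on CHO cells for agonist activity at Alpha-1A adrenergic receptor (Homo sapiens), read by FLIPR and calcium flux (on this read-out lower numbers stand for an effect already at smaller amounts and higher numbers for an effect only at larger amounts of compound), the higher of the two numbers measured so far. Compound 1 `Cc1n[nH]cc1-c1cccc2c1CCC2c1ncc[nH]1`, which bears 3-methyl-1H-pyrazol-4-yl in the same place, gives 3 nM, and the step of a 17-fold higher number from compound 1 to compound 2 (1.24 log units; beyond the scatter) shows how strongly the pattern of the pyrazole matters. Compound 3 `Cn1ccc(-c2cccc3c2CCC3c2ncc[nH]2)n1` has not yet been measured; it differs from compound 2 in that (1-methyl-1H-pyrazol-3-yl in place of 1H-pyrazol-5-yl on an aromatic carbon). Going by the values given here, only the step of a 17-fold higher number from compound 1 to compound 2 (1.24 log units; beyond the scatter) bears on this change, and it concerns a different pyrazole pattern, so it points to a direction only loosely. Among the compounds with values here, a modest change is expected, a 1.3-fold lower number from compound 2 to compound 3 (0.11 log units; within the scatter), with a wide range because the single step of a 17-fold higher number from compound 1 to compound 2 (1.24 log units; beyond the scatter) was large. Compound 3 is therefore estimated at 40 nM, between 5 nM and 300 nM.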

Compound 3, half-maximal effective concentration: > 1300 nM
Compound 3 gave a limit, no number; the forecaster's own chance of this, stated with the estimate: 5%; middle value at least 32-fold (1.51 log units) away from the limit.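

In this assay compound 3 gives > 1300 nM, a limit of the assay and not a number. Even so, placing 1-methyl-1H-pyrazol-3-yl in place of 1H-pyrazol-5-yl produces an at least 25-fold higher number from compound 2 to compound 3 (1.39 log units; beyond the scatter), so a second pyrazole exchange on this aromatic carbon also moves the read-out well beyond the scatter. Measured against the other pyrazole, 3-methyl-1H-pyrazol-4-yl, the gap widens to an at least 430-fold higher number from compound 1 to compound 3 (2.63 log units; beyond the scatter), which makes the position sensitive to the pyrazole it carries in all three compounds shown.

The exchange between compound 2 and compound 3 replaces a group with 1 hydrogen-bond donor by one with 0 and also brings in a methyl, and these compounds cannot tell which of the two matters. Also open, as far as these compounds go, is how an amine or a carboxylic acid on this aromatic carbon, in place of a pyrazole, would read in this assay.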